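This account rests on a few compounds, and the source may have more. Where it says the series, first, only, none or still open, it means among the compounds named here.

Compound 1 `CN(C)CCn1cnnc1-c1cc(Oc2ccc(NC(=O)N/N=C/c3ccc(Cl)cc3Cl)cc2F)ccn1` gives 130 nM in a functional assay on NCI-H460 cells (Homo sapiens) for cytotoxicity, read by MTT assay, with a stated time of 72 h; on this read-out higher numbers stand for weaker inhibition and lower numbers for stronger inhibition.
Compound 2 `CN(C)CCn1cnnc1-c1cc(Oc2ccc(NC(=O)N/N=C/c3ccc(O)c(Br)c3)cc2F)ccn1` gives 430 nM.
Compound 3 `CN(C)CCn1cnnc1-c1cc(Oc2ccc(NC(=O)N/N=C/c3ccc(O)c(O)c3)cc2F)ccn1` gives 1930 nM.

Compound 2 stands second highest of the three numbers: compound 1 lies below it by a 3.3-fold higher number from compound 1 to compound 2 (0.52 log units; beyond the scatter), and compound 3 above it by a 4.5-fold higher number from compound 2 to compound 3 (0.65 log units; beyond the scatter). Compound 4 `COc1ccc(/C=N/NC(=O)Nc2ccc(Oc3ccnc(-c4nncn4CCN(C)C)c3)c(F)c2)cc1O` has not been measured in this assay. It differs from compound 2 as follows: 3-hydroxy-4-methoxyphenyl in place of 3-bromo-4-hydroxyphenyl on a carbon with a double bond to nitrogen. The step that bears on this is the one with hydroxy in place of bromo, which gave a 4.5-fold higher number from compound 2 to compound 3 (0.65 log units; beyond the scatter), with a 15-fold higher number from compound 1 to compound 3 (1.17 log units; beyond the scatter) pointing the same way. A modest upward step is therefore expected, estimated at a 2.8-fold higher number from compound 2 to compound 4 (0.45 log units; beyond the scatter). Compound 4 is expected to give about 1200 nM, within a range of 500 nM to 3000 nM.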

Compound 4, half-maximal inhibitory concentration: 620 nM
For compound 4 the middle estimate is 1.9-fold (0.29 log units) above the measured one; measured number inside the range.
By their numbers in this assay, from the lowest: compound 1; then compounds 2 and 4 (each within the scatter of the next); then compound 3.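

In this assay, 3-hydroxy-4-methoxyphenyl and 3-bromo-4-hydroxyphenyl on this carbon cannot be told apart (a 1.4-fold higher number from compound 2 to compound 4 (0.16 log units; within the scatter)), so bromo is not required to hold this level. Methyl in place of hydrogen on the oxygen gives a clear gain (a 3.1-fold lower number from compound 3 to compound 4 (0.49 log units; beyond the scatter)), although 2,4-dichlorophenyl remains ahead (a 4.8-fold higher number from compound 1 to compound 4 (0.68 log units; beyond the scatter)). Nothing at hand explains these steps. Still open, going by these compounds, is whether a single methoxy, without the hydroxy, would hold this level. Also open, on these data alone, is how a phenyl ring carrying an amine or a carboxylic acid would fare on this carbon.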